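Turning One Stereocentre in Compound 1

This account rests on a few compounds, and the source may have more. Where it says the series, first, only, none or still open, it means among the compounds named here.

Among the compounds with values here, in a functional assay on SK-OV-3 cells (Homo sapiens) for inhibition, read by MTT assay (on this read-out higher numbers stand for weaker inhibition and lower numbers for stronger inhibition), compound 1 `COc1ccc(/C=C2\c3cc(OC)c(OC)c(OC)c3CC[C@@H]2O)cc1C#N` gives 20 nM, the lower of the two numbers so far, and compound 2 `COc1ccc(/C=C2\c3cc(OC)c(OC)c(OC)c3CC[C@@H]2O)cc1C` gives 730 nM. Compound 3 `COc1ccc(/C=C2\c3cc(OC)c(OC)c(OC)c3CC[C@H]2O)cc1C#N` has the same atoms and bonds as compound 1: the two compounds have the same atoms and bonds and differ only in configuration as drawn: 1 of 2 stereo elements differ; a stereocentre at a saturated ring carbon is drawn S in compound 1 and R in compound 3. Within the data shown here, the only measured step, a 37-fold higher number from compound 1 to compound 2 (1.56 log units; beyond the scatter), comes with methyl in place of cyano on an aromatic carbon. It shows that these numbers can move far, but it does not test configuration, so the size of any change remains uncertain. The expected step is a 4.0-fold higher number from compound 1 to compound 3 (0.60 log units; beyond the scatter). For compound 3 the estimated value is 80 nM, with an expected range of 15 nM to 700 nM.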

Compound 3, half-maximal inhibitory concentration: 600 nM
For compound 3 the middle estimate is 7.5-fold (0.88 log units) below the measured one; measured number inside the range.
By their numbers in this assay, from the lowest: compound 1; then compounds 3 and 2 (each within the scatter of the next).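

In this assay the result is a 30-fold higher number from compound 1 to compound 3 (1.48 log units; beyond the scatter), so the arrangement at this saturated ring carbon matters on its own, with no atom added or removed. Until now only methyl in place of cyano had moved the number this far, and compound 3 and compound 2 now lie within the scatter of each other. The step can be assigned to configuration alone because of one fact: the fact that compounds 1 and 3 differ only in the configuration as drawn.

From the compounds shown here alone, whether the hydroxyl itself is needed at this carbon remains open, as an amine or a methyl ether there could answer. Also open, going by these compounds, is whether configuration matters as much with methyl in place of cyano.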